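This account rests on a few compounds, and the source may have more. Where it says the series, first, only, none or still open, it means among the compounds named here.

For the measured compounds named here, compound 1 `Cc1ccc(S(=O)(=O)Oc2c(-c3ccccc3)c(-c3ccccc3)n3ccc(C#N)cc23)cc1` is the only member of this small set with a number in an assay for inhibition of Polyunsaturated fatty acid lipoxygenase ALOX15 (Oryctolagus cuniculus); on this read-out higher numbers stand for weaker inhibition and lower numbers for stronger inhibition: in this assay compound 1 gives 25000 nM. Compound 2 `COc1cccc(-c2c(-c3ccccc3)c(-c3ccccc3)n3ccc(C#N)cc23)c1` has in this assay only the entry "not determined" (no result reported), and compound 3 `COc1ccccc1COc1c(-c2ccccc2)c(-c2ccccc2)n2ccc(C#N)cc12` likewise has in this assay only the entry "not determined" (no result reported). Compound 4 `N#Cc1ccn2c(-c3ccccc3)c(-c3ccccc3)c(C(=O)c3ccccc3)c2c1` has not yet been tested. From compound 3 to compound 4 the change is benzoyl in place of (2-methoxybenzyl)oxy on an aromatic carbon. Going by the values given here, with no measured step anywhere in the set, neither the size nor the direction of this change in this assay can be read from a neighbour; only the single result of compound 1, 25000 nM, hints at the level this core reaches. Compound 4 is therefore expected to give roughly 15000 nM in this assay, estimated to fall between 2000 nM and 100000 nM.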

Compound 4, half-maximal inhibitory concentration: 43000 nM
Compound 4: the middle estimate sits 2.9-fold (0.46 log units) below what was measured; low and high end bracket the measured number.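

Benzoyl in place of ((4-methylphenyl)sulfonyl)oxy on this aromatic carbon gives a 1.7-fold higher number from compound 1 to compound 4 (0.24 log units; within the scatter) in this assay. For the compounds shown here, this is the first readable step at the position, and it does not separate the two groups, although the sulfonyl link is gone from compound 4. Nothing shown here gives a cause for this result. Still open, from the compounds shown here alone, is whether an amine, a carboxylic acid or a longer chain on this aromatic carbon would move the number beyond the scatter. The compounds shown also leave the phenyl groups and the nitrile of the shared core unvaried.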